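The source may hold more compounds than are shown below. What is called first, only, known or untested is meant among the compounds shown, and "the series" means these compounds.

In a functional assay on KB cells (Homo sapiens) for inhibition, read by sulforhodamine B assay, with a stated time of 72 h (a lower number here means a stronger inhibitor of growth, a higher number a weaker inhibitor of growth), compound 1 `CCOC(=O)/C=C/c1ccncc1-c1ccc2c(cnn2C)c1` gives > 10000 nM, which is a limit of the assay and not a number. Compound 2 `O=C(O)/C=C/c1ccncc1-c1ccc2ccccc2c1` gives > 10000 nM, also a limit. Compound 2 thus stands at the limit of > 10000 nM in this assay, at which 2 of the 2 values shown sit. Compound 3 `CN(C)C(=O)/C=C/c1ccncc1-c1ccc2ccccc2c1` differs from it in one place, with dimethylamino in place of hydroxy on a carbonyl carbon, turning carboxy into dimethylcarbamoyl: dimethylamino in place of hydroxy on a carbonyl carbon. For the measured compounds named here, no measured pair shows what this change does. In this assay the expected change is small, perhaps a slightly stronger inhibitor of growth, with an estimated at least 1.2-fold lower number from compound 2 to compound 3 (0.09 log units; that floor lies within the scatter). For compound 3 the estimated value is 8000 nM, with an expected range of 2000 nM to 30000 nM.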

Compound 3, concentration for 50% growth inhibition: 7760 nM
Compound 3: the middle estimate sits 1.0-fold (0.01 log units) above what was measured; low and high end bracket the measured number.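

Compound 3 gives the first measured number among the compounds shown in this assay, so a dimethylcarbamoyl group on this chain brings growth inhibition within the range the test can read. Compound 2 gives > 10000 nM, which is a limit of the assay and not a number. The step can therefore be stated only as an at least 1.2-fold lower number from compound 2 to compound 3 (0.11 log units; that floor lies within the scatter), and this floor fixes no exact size for the change.

From the compounds shown here alone, it remains open how methylamino or morpholine on the same carbonyl carbon would compare with dimethylamino in this assay.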